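A few compounds are considered here, and "the series" means these few. Any claim that something is new, unique, unknown or untested is made for them only; others in the source may bear on it.

In a physicochemical assay for lipophilicity (on this read-out higher numbers stand for higher lipophilicity and lower numbers for lower lipophilicity), compound 1 `O=C1/C(=C/c2ccc(F)cc2)CCC/C1=C\c1ccccc1[N+](=O)[O-]` gives 4.86 while compound 2 `CN(C)c1ccc(/C=C2\CCC/C(=C\c3ccccc3[N+](=O)[O-])C2=O)cc1` gives 4.8 and compound 3 `O=C1/C(=C/c2ccccc2)CCC/C1=C\c1cccc([N+](=O)[O-])c1` gives 4.9 on the same scale. These three numbers all lie within the usual scatter of one another, so compound 3 stands level with the other two and not apart from them.

Compound 4 `Cc1ccc(/C=C2\CCC/C(=C\c3cccc([N+](=O)[O-])c3)C2=O)cc1` differs from compound 3 by one small edit, methyl in place of hydrogen on an aromatic carbon which amounts to methyl in place of hydrogen on an aromatic carbon, para to a large group.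

Within the data shown here, only one measured step bears on this, and only loosely. It is a number 0.06 log units lower from compound 1 to compound 2 (within the scatter) for dimethylamino in place of fluoro on an aromatic carbon, and that swap stayed within the scatter. Among the measured compounds shown here, no measured pair tests methyl directly, so the expectation is a modest one. The expected step is a number 0.30 log units higher from compound 3 to compound 4 (within the scatter) in the upward direction, and it could stay close to the scatter. For compound 4 the estimated value is 5.2 with an expected range from 4.85 to 5.55 in this read-out.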

Compound 4, partition coefficient: 5.35
For compound 4 the middle estimate is 0.15 log units below the measured one, and the stated range covers the measured number.
By their numbers in this assay, from the lowest: compounds 2, 1 and 3 (each within the scatter of the next); then compound 4.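

In this assay, among these compounds, the change of phenyl to 4-methylphenyl, with methyl in place of hydrogen on an aromatic carbon para to a large group, gives a number 0.45 log units higher from compound 3 to compound 4 (beyond the scatter) and is the first step here to pass beyond the scatter. Among the compounds shown here, the only earlier step, a number 0.06 log units lower from compound 1 to compound 2 (within the scatter) for dimethylamino in place of fluoro on an aromatic carbon, gave no sign that a single swap on such a carbon could shift this read-out clearly, whereas one added carbon now does. Nothing measured here explains why the number moves this far.

On these data alone, whether an ethyl group, a longer chain or a carboxylic acid on this same carbon would shift the number as far remains open. So does whether methyl would give a similar step with the nitro-bearing ring of compound 1 in place of the one in compound 3.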